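Aryl change on the ring amine: nitro to trifluoromethyl

The compounds below may be only part of what the source reports. "The series", "measured", "known", "first", "only" and "open" are said of these compounds alone.

Compound 3 `Nc1scc(CN2CCN(c3ccc([N+](=O)[O-])cc3)CC2)c1C(=O)c1ccc(Cl)cc1` gives -17% in a functional assay on CHO cells with adenosine receptor A1 (Homo sapiens) as the target, read by cAMP accumulation and immunoassay, with a stated time of 6 min, tested at 10 uM (on this read-out higher numbers stand for a weaker effect at the one concentration tested and lower numbers for a stronger effect), the highest of the three numbers: compound 1 `Nc1scc(CN2CCN(c3ccc(Cl)cc3Cl)CC2)c1C(=O)c1ccc(Cl)cc1` gives -74% and compound 2 `Nc1scc(CN2CCN(c3cccc(Cl)c3Cl)CC2)c1C(=O)c1ccc(Cl)cc1` gives -77%. Compound 4 `Nc1scc(CN2CCN(c3cccc(C(F)(F)F)c3)CC2)c1C(=O)c1ccc(Cl)cc1` differs from compound 3 as 3-(trifluoromethyl)phenyl in place of 4-nitrophenyl on an amine nitrogen in a ring. Among the compounds with values here, two measured steps bear on this, both reaching compound 3 when the 4-nitrophenyl entered: a number 57 percentage points higher from compound 1 to compound 3 (beyond the scatter) and a number 60 percentage points higher from compound 2 to compound 3 (beyond the scatter), whereas a number 3 percentage points lower from compound 1 to compound 2 (within the scatter). Within the data shown here, no measured compound carries 3-(trifluoromethyl)phenyl, so its own effect is not known; since in both steps the number rose when the 4-nitrophenyl entered, its departure is expected to bring a large step downward, with wide uncertainty. For compound 4 in this assay a value of -50% is expected, range -85% to -10%, a step of a number 33 percentage points lower from compound 3 to compound 4 (beyond the scatter) being estimated.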

Compound 4, a percentage reported as activity, at one concentration (the size of the read-out at that concentration, not a potency): -80%
Beside the measured number, compound 4's estimate is 30 percentage points above it, within the range that was stated.
By their numbers in this assay, from the lowest: compounds 4, 2 and 1 (each within the scatter of the next); then compound 3.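

The change of aryl group on the amine nitrogen in the ring gives a large shift (a number 63 percentage points lower from compound 3 to compound 4 (beyond the scatter)), so the weak effect of compound 3 does not extend to every singly substituted phenyl group. Chlorine on this aryl group is not required, as 3-(trifluoromethyl)phenyl matches both dichlorophenyl groups (a number 3 percentage points lower from compound 2 to compound 4 (within the scatter)) and (a number 6 percentage points lower from compound 1 to compound 4 (within the scatter)), leaving compound 3 as the only outlier among the four compounds. Nothing measured here explains why 4-nitrophenyl stands apart.

Left open is whether the nitro group itself or its place on the aryl ring sets compound 3 apart. Also open, from the compounds shown here alone, is how a methoxy group or an amine on that aryl ring would compare.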